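A few compounds are considered here, and "the series" means these few. Any claim that something is new, unique, unknown or untested is made for them only; others in the source may bear on it.

Compound 1 `CCNC(=O)c1noc(-c2cc(C(C)C)c(O)cc2O)c1-c1cc(COCC(N)=O)no1`: "not determined" (no result reported)
Compound 2 `CCNCc1cc(-c2c(C(=O)NCC)noc2-c2cc(C(C)C)c(O)cc2O)on1`: 45 nM

These results come from a functional assay on A2780 cells (Homo sapiens) for inhibition; on this read-out lower numbers stand for stronger inhibition and higher numbers for weaker inhibition. For the measured compounds named here, compound 2 gives 45 nM, the only actual number in this small set. Compound 1 has no reported result, so it offers no comparison, and nothing yet shows whether compound 2 is strong or weak relative to close relatives.

The next molecule, compound 3 `C=CNCc1cc(-c2c(C(=O)NCC)noc2-c2cc(C(C)C)c(O)cc2O)on1`, keeps the shared core of compound 2 and alters a single group: vinyl in place of ethyl on an amine nitrogen. Going by the values given here, no measured pair shows what such a swap does in this assay, so the expectation is anchored only on compound 2 at 45 nM. With so little evidence, no change beyond the usual scatter is expected, with perhaps a slight loss of inhibition. The estimated change is a 1.3-fold higher number from compound 2 to compound 3 (0.12 log units; within the scatter). For compound 3 the expected value is 60 nM, within an estimated range of 20 nM to 180 nM.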

Compound 3, half-maximal inhibitory concentration: 43 nM
Estimate against measurement, compound 3: 1.4-fold (0.14 log units) above; the measured number falls inside the stated range.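

In this assay, for the compounds shown here, vinyl in place of ethyl on the amine nitrogen gives a 1.0-fold lower number from compound 2 to compound 3 (0.02 log units; within the scatter), the first measured comparison at this position. The two compounds cannot be told apart here, so in this single pair, a double bond in this two-carbon group leaves the read-out unchanged within normal scatter. Nothing available explains why the two groups read alike.

A single pair cannot show how much change this nitrogen substituent allows, so a longer chain such as butyl, a small ring such as cyclopropyl, or a bare primary amine could give quite a different result. On these data alone, it also remains open whether the same swap would read alike on other compounds, and compound 1 has no number to add to the comparison.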